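Carboxy to sulfamoyl on the aryl of the shared core

A few compounds are considered here, and "the series" means these few. Any claim that something is new, unique, unknown or untested is made for them only; others in the source may bear on it.

Measured compounds in a functional assay on the whole organism for inhibition, with Rattus norvegicus as the target, read by paw edema, with a stated time of 3 h, at a dose of 50 mg/kg by the oral route; a lower number here means less inhibition, a higher number more inhibition at the dose given (going by the name of the read-out):
compound 1, `CS(=O)(=O)c1ccc(C2=NN(c3ccc(C(=O)O)cc3)C(c3ccc(F)cc3)C2)cc1`: 42.3%
compound 2, `CS(=O)(=O)c1ccc(C2=NN(c3ccc(C(=O)O)cc3)C(c3ccc(Cl)cc3)C2)cc1`: 50.4%
compound 3, `CS(=O)(=O)c1ccc(C2=NN(c3ccc(C(=O)O)cc3)C(c3cccs3)C2)cc1`: 35.6%

Among these three numbers compound 1 sits between the other two, yet its gaps to both lie within the scatter: a number 8.1 percentage points higher from compound 1 to compound 2 (within the scatter) and a number 6.7 percentage points lower from compound 1 to compound 3 (within the scatter). Among the compounds with values here, the only step beyond the scatter is a number 14.8 percentage points lower from compound 2 to compound 3 (beyond the scatter), a modest one. All three measured steps change the group on the saturated ring carbon of the core; none touches the group on the aromatic carbon.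

Compound 4, `CS(=O)(=O)c1ccc(C2=NN(c3ccc(S(N)(=O)=O)cc3)C(c3ccc(F)cc3)C2)cc1`, differs from compound 1 at that aromatic carbon: sulfamoyl in place of carboxy on an aromatic carbon. Within the data shown here, no measured step bears on this change, so there is no basis for expecting a shift beyond the scatter in this assay in either direction. The expectation therefore rests on the value of compound 1 alone, widened for the lack of any comparable step.

Compound 4 is expected to give 42%, in a range from 24% to 60%. This estimate means a number 0.3 percentage points lower from compound 1 to compound 4 (within the scatter), expected to stay within the scatter.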

Compound 4, a percentage reported as inhibition, in the whole organism at one dose (the size of the read-out at that dose, not a potency): 65.7%
Estimate against measurement, compound 4: 23.7 percentage points below; the measured number lies above the stated range.
By their numbers in this assay, from the lowest: compounds 3, 1 and 2 (each within the scatter of the next, the first and the last beyond it); then compound 4.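

Within the data shown here, the aromatic carbon para to a large group, untouched by the earlier steps, proves responsive in this assay: a number 23.4 percentage points higher from compound 1 to compound 4 (beyond the scatter) for sulfamoyl in place of carboxy. Compounds 1, 2 and 3 all carry carboxy, so they could show only what the group on the saturated ring carbon does, and the result now shows that a carboxy group is not needed at this position for inhibition of paw edema at the dose given. No measurement at hand bears on what lies behind this step.

On these data alone, whether sulfamoyl gives a similar step with 4-chlorophenyl or thiophen-2-yl on the saturated ring carbon remains open. Also open, as far as these compounds go, is how a primary carboxamide, a methyl ester or a methylsulfonyl group at this aromatic carbon would compare with sulfamoyl in this assay.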